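This account rests on a few compounds, and the source may have more. Where it says the series, first, only, none or still open, it means among the compounds named here.

In a functional assay on CHO-K1 cells for antagonist activity at adenosine receptor A1 (Homo sapiens), read by a beta-galactosidase reporter and cAMP accumulation, with stated times of 15 min and 6 h (on this read-out higher numbers stand for weaker inhibition and lower numbers for stronger inhibition), compound 1 `Nc1nc(-c2ncco2)nc2sc(Cc3ccccc3)cc12` gives 310 nM, and compound 2 `N#Cc1cccc(-c2nc(N)c3cc(Cc4ccccc4)sc3n2)c1` gives 222 nM. Within the data shown here, the only measured step, a 1.4-fold lower number from compound 1 to compound 2 (0.15 log units; within the scatter), lies within the scatter, so on these two numbers compound 2 stands lowest but not apart from compound 1. Compound 3 `C=C(c1ccccc1)c1cc2c(N)nc(-c3cccc(C#N)c3)nc2s1` is not yet measured. Among the measured compounds shown here, it differs from compound 2 by 1-phenylethenyl in place of benzyl on an aromatic carbon, a change at a site untouched by the one measured step, which altered the group on the aromatic carbon at the other end of the shared core. For the measured compounds named here, no measured step therefore bears on this change, and there is no ground to expect a shift beyond the scatter in this assay in either direction. Compound 3 is accordingly estimated at 250 nM, within a range from 80 nM to 800 nM, which corresponds to an expected step of a 1.1-fold higher number from compound 2 to compound 3 (0.05 log units; within the scatter).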

Compound 3, inhibition constant: > 1000 nM
Compound 3: a limit, no number (the forecaster's own chance of this, stated with the estimate: 5%); middle value at least 4.0-fold (0.60 log units) from the limit.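

Among these compounds, the position next to the ring sulfur, which the one earlier step did not touch, proves sensitive in this assay: 1-phenylethenyl in place of benzyl brings an at least 4.5-fold higher number from compound 2 to compound 3 (0.65 log units; beyond the scatter). The two groups share one six-membered aromatic ring of carbon only and differ in the double bond outside aromatic rings, so even a change that keeps this ring can move the read-out beyond the scatter here. For compound 3 the result is a limit of the assay and not a number: the limit of > 1000 nM in this assay, at which 1 of the 3 values shown sits.

The compounds shown leave open whether the double bond itself or the branching at the attached carbon accounts for the step, which a 1-phenylethyl group would help to separate. They also leave open how a carbonyl linker, as in benzoyl, or a longer chain such as 2-phenylethyl would fare at this position.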